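Chloro for trifluoromethyl on the benzyl ring of compound 2

A few compounds are considered here, and "the series" means these few. Any claim that something is new, unique, unknown or untested is made for them only; others in the source may bear on it.

Compound 2 `CCCn1c(=O)c2nc(-c3cnn(Cc4cc(C(F)(F)F)ccc4Cl)c3)[nH]c2n(CCC)c1=O` stands at the highest number of the three measured compounds in an assay on CHO cells for displacement of a labelled ligand from adenosine receptor A1 (Homo sapiens) (on this read-out higher numbers stand for weaker inhibition and lower numbers for stronger inhibition), where compound 2 gives 1200 nM. Among the measured compounds shown here, compound 1 `CC(C)Cn1c(=O)c2nc(-c3cnn(Cc4cccc(F)c4)c3)[nH]c2n(CC(C)C)c1=O` gives 830 nM in this assay, within the scatter of compound 2, and differs from it in both chains and in the benzyl ring, so no single step connects the two. For the measured compounds named here, compound 3 `CCCn1c(=O)c2nc(-c3cnn(Cc4ccccc4C(F)(F)F)c3)[nH]c2n(CCC)c1=O` gives 44 nM in this assay, and the one clean step in the set is a 27-fold lower number from compound 2 to compound 3 (1.44 log units; beyond the scatter), the change being 2-(trifluoromethyl)phenyl in place of 2-chloro-5-(trifluoromethyl)phenyl.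

Compound 4 `CCCn1c(=O)c2nc(-c3cnn(Cc4cc(Cl)ccc4Cl)c3)[nH]c2n(CCC)c1=O` has not been measured. It differs from compound 2 in one place: chloro in place of trifluoromethyl on an aromatic carbon. Going by the values given here, the step from compound 2 to compound 3 removes the chloro and relocates the trifluoromethyl, so it does not show what swapping one group for the other at a fixed position does; the set holds no step of that kind. With the chloro group retained and the large group simply replaced by a smaller one, no step beyond the scatter is expected in this assay. Compound 4 is therefore estimated at 900 nM, with a range of 300 nM to 3000 nM. This estimate means a step of a 1.3-fold lower number from compound 2 to compound 4 (0.12 log units; within the scatter), expected to lie within the scatter.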

Compound 4, inhibition constant: 190 nM
Compound 4: middle estimate off by 4.7-fold (0.68 log units), on the high side; measured number outside the range, below it.
By their numbers in this assay, from the lowest: compound 3; then compound 4; then compounds 1 and 2 (each within the scatter of the next).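

In this assay, the exchange of trifluoromethyl for chloro at one fixed aromatic carbon, para to a chloro group, can now be read on its own: chloro in place of trifluoromethyl gives a 6.3-fold lower number from compound 2 to compound 4 (0.80 log units; beyond the scatter), so this position of the benzyl ring does distinguish between the two groups. That change covers only part of a 27-fold lower number from compound 2 to compound 3 (1.44 log units; beyond the scatter), since the 2,5-dichlorophenyl group still stands apart from 2-(trifluoromethyl)phenyl, with a 4.3-fold higher number from compound 3 to compound 4 (0.64 log units; beyond the scatter). No measurement at hand accounts for the difference between the two groups at this carbon.

Still open, as far as these compounds go, is how a methoxy group or an amine would read at this carbon, and what the chloro group alone contributes, as the step between the 2,5-dichlorophenyl and 2-(trifluoromethyl)phenyl groups alters the ring at more than one carbon. Also open, from the compounds shown here alone, is whether the exchange of trifluoromethyl for chloro would give a step of similar size on the chains of compound 1, which so far connects to the other compounds through no single change.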